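Phenyl in place of propyl on a shared core

The source may hold more compounds than are shown below. What is called first, only, known or untested is meant among the compounds shown, and "the series" means these compounds.

For the measured compounds named here, compound 1 `CCCCn1cnc2c(NCc3ccc(C(=O)Nc4ccccc4N)cc3)nc(Cl)nc21` stands lowest of the three numbers known so far in a functional assay on NCI-H460 cells (Homo sapiens) for antiproliferative activity, read by CCK-8 assay, with a stated time of 72 h, tested at 8 uM; on this read-out lower numbers stand for a weaker effect and higher numbers for a stronger effect at the one concentration tested; in that assay compound 1 gives 23.7%. The nearest number belongs to compound 3 `CCCCn1cnc2c(Nc3ccccc3)nc(NCOCc3ccc(/C=C/C(=O)Nc4ccccc4N)cc3)nc21`, which gives 34.2% in this assay, a gap beyond the usual scatter. The furthest belongs to compound 2 `Nc1ccccc1NC(=O)/C=C/c1ccc(COCNc2nc(Nc3cccc(Cl)c3)c3ncn(C4CCCC4)c3n2)cc1`, which gives 46.1% in this assay, also beyond the scatter. Going by the values given here, both of those compounds carry a different linker and a different amide than compound 1, so they say little about the single change considered here.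

Compound 4 `Nc1ccccc1NC(=O)c1ccc(CNc2nc(Cl)nc3c2ncn3Cc2ccccc2)cc1` has not yet been measured. It differs from compound 1 in one place: phenyl in place of propyl on a saturated chain carbon bound to an aromatic nitrogen. Among the compounds with values here, no measured pair shows this same change, so the numbers give no direct guide to its size. The expected step in this assay is a number 4.3 percentage points higher from compound 1 to compound 4 (within the scatter), a small rise that stays within the scatter of repeated measurements. Compound 4 is therefore estimated at 28% in this assay, with a likely range from 12% to 46%.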

Compound 4, a percentage reported as inhibition, at one concentration (the size of the read-out at that concentration, not a potency): 46.4%
For compound 4 the middle estimate is 18.4 percentage points below the measured one; the whole stated range lies below it.
By their numbers in this assay, from the lowest: compound 1; then compound 3; then compounds 2 and 4 (each within the scatter of the next).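

In this assay, putting phenyl in place of propyl on a saturated chain carbon bound to an aromatic nitrogen gives a number 22.7 percentage points higher from compound 1 to compound 4 (beyond the scatter) and is the only step shown at this position. The read-out therefore responds to what sits here: the change, which can also be read as butyl to benzyl, brings in a six-membered aromatic ring of carbon only, and the shift is larger than repeated measurements would produce by chance. No measurement at hand accounts for the step, so it stands as an observation without an explanation.

A single step cannot separate the effect of the ring from that of the added carbon atoms. Going by these compounds, whether a longer chain such as hexyl, a saturated cyclohexyl ring or a chain ending in an amine would match phenyl stays open.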